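This account rests on a few compounds, and the source may have more. Where it says the series, first, only, none or still open, it means among the compounds named here.

Notes on the series. For the measured compounds named here, compound 1 `CC(=O)c1ccc(/C=C2\CCCN=C2c2cccnc2)cc1` carries an acetyl on the phenyl ring of the shared core; in an assay on membranes from brain for displacement of a labelled ligand from Neuronal acetylcholine receptor; alpha4/beta2 (Rattus norvegicus), with a stated time of 3 h (on this read-out lower numbers stand for stronger inhibition and higher numbers for weaker inhibition), compound 1 gives 4490 nM, the highest of the two numbers so far. Going by the values given here, compound 2 `CCN(CC)c1ccc(/C=C2\CCCN=C2c2cccnc2)c(O)c1` gives 130 nM in this assay, a markedly lower number, but the two structures differ in more than one place, so no single step is read from the pair. Compound 3 `C(=C1\CCCN=C1c1cccnc1)\c1ccccc1` is the next case: hydrogen in place of acetyl on an aromatic carbon. The step of a 3.0-fold lower number from compound 1 to compound 3 (0.48 log units; beyond the scatter) is expected to be modest, toward lower numbers, near the edge of the scatter. Compound 3 is estimated at 1500 nM, within 400 nM to 5000 nM.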

Compound 3, inhibition constant: 850 nM
Estimate against measurement, compound 3: 1.8-fold (0.25 log units) above; the measured number falls inside the stated range.
By their numbers in this assay, from the lowest: compound 2; then compound 3; then compound 1.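

Notes on the step. In this assay, for the compounds shown here, the first change that can be read in one place is a 5.3-fold lower number from compound 1 to compound 3 (0.72 log units; beyond the scatter), with hydrogen in place of acetyl on an aromatic carbon, para to a large group. The lower number comes with no group at this carbon, so the acetyl is not needed to reach it. Nothing measured here bears on why the number falls.

Going by these compounds, whether an amine, a carboxylic acid or a methoxy group at this carbon would give a lower or a higher number stays open. So does whether the same step holds with other groups elsewhere on the phenyl ring.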